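Swapping an isopropyl for hydrogen on compound 2

The source may hold more compounds than are shown below. What is called first, only, known or untested is meant among the compounds shown, and "the series" means these compounds.

Compound 1 `COc1ccc(C(=O)/C=C/c2csc3ccccc23)c(O)c1`: 7400 nM
Compound 2 `COc1c(OC(C)C)cc2c(c1OC(C)C)C(=O)/C(=C/c1csc3ccccc13)O2`: > 10000 nM (a limit)

In a functional assay on MDA-MB-231 cells (Homo sapiens) for antiproliferative activity, read by sulforhodamine B assay, with a stated time of 72 h (a lower number here means a stronger inhibitor, a higher number a weaker inhibitor), compound 2 reads > 10000 nM, which is a limit of the assay and not a number. Compound 3 `COc1c(OC(C)C)cc2c(c1O)C(=O)/C(=C/c1csc3ccccc13)O2` changes one place in compound 2: hydrogen in place of isopropyl on an oxygen on an aromatic ring. This puts hydrogen in place of isopropyl on an oxygen on an aromatic ring, turning isopropoxy to hydroxy. Going by the values given here, no measured pair shows this change, so only a modest strengthening in this assay is expected, and compound 1 at 7400 nM is the only true number to gauge it by. The expected change is an at least 2.0-fold lower number from compound 2 to compound 3 (0.30 log units; that floor lies within the scatter). For compound 3 the estimated value is 5000 nM, with an expected range of 1000 nM to 10000 nM.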

Compound 3, half-maximal inhibitory concentration: > 10000 nM
Compound 3: a limit, no number; the forecaster's own chance of this, stated with the estimate: 30%; middle value at least 2.0-fold (0.30 log units) away from the limit.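

Compound 2 and compound 3 both read as limits, not numbers, so the step between them cannot be read: the limit of > 10000 nM in this assay, at which 2 of the 3 values shown sit. From the compounds shown here alone, whether hydroxy in place of isopropoxy changes the activity at all stays open.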